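Removing a Methoxymethyl Group in an Antiproliferative Series

This account rests on a few compounds, and the source may have more. Where it says the series, first, only, none or still open, it means among the compounds named here.

In a functional assay on MCF7 cells (Homo sapiens) for antiproliferative activity, with a stated time of 72 h (on this read-out higher numbers stand for weaker inhibition and lower numbers for stronger inhibition), compound 1 `C=C[C@@H]1C[C@@H](Cc2ccc(OC)c(O)c2)[C@H]2C(=O)C=CC(=C)[C@H]21` gives 1.17 nM. On the same read-out, compound 2 `C=C1C=CC(=O)[C@@H]2[C@H](Cc3ccc(OCOC)cc3)CC[C@H]12` gives 63.6 nM, the higher of the two numbers, and its gap to compound 1 lies beyond the scatter. Compound 3 `C=C1C=CC(=O)[C@@H]2[C@H](Cc3cc(OC)c(OC)c(OC)c3)CC[C@H]12` is reported only as a limit, > 1000 nM.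

The next compound to be tested, compound 4 `C=C1C=CC(=O)[C@@H]2[C@H](Cc3ccc(O)cc3)CC[C@H]12`, differs from compound 2 at a single place: hydrogen in place of methoxymethyl on an oxygen on an aromatic ring. This puts hydrogen in place of methoxymethyl on an oxygen on an aromatic ring, turning methoxymethoxy into hydroxy.

For the measured compounds named here, no measured pair isolates this change, so the expectation rests on indirect evidence. Compound 1 also carries a hydroxy on its aromatic ring and gives 1.17 nM, but it differs from compound 4 elsewhere too, so only a moderate shift toward stronger inhibition in this assay is anticipated. The expected change is a 3.2-fold lower number from compound 2 to compound 4 (0.50 log units; beyond the scatter). The estimated value for compound 4 is 20 nM, with an expected range of 3 nM to 150 nM.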

Compound 4, half-maximal inhibitory concentration: 33.8 nM
Compound 4: the middle estimate sits 1.7-fold (0.23 log units) below what was measured, and the stated range covers the measured number.
By their numbers in this assay, from the lowest: compound 1; then compounds 4 and 2 (each within the scatter of the next). At a limit, above all of these: compound 3.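

In this assay, the step is a 1.9-fold lower number from compound 2 to compound 4 (0.27 log units; within the scatter). For the compounds shown here, this is the first direct reading of this change, and it shows that on this oxygen on an aromatic ring, methoxymethoxy and hydroxy cannot be told apart on this read-out: removing the methoxymethyl group neither clearly strengthens nor clearly weakens inhibition. Nothing shown here gives a cause for this outcome.

Compound 1 differs from compound 4 in more than one place, so the compounds shown do not say which of those differences goes with its number. On these data alone, it also remains open whether a longer chain on this oxygen, or an amine or a carboxylic acid in place of the hydroxy, would give a number beyond the scatter of these two compounds.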